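A few compounds are considered here, and "the series" means these few. Any claim that something is new, unique, unknown or untested is made for them only; others in the source may bear on it.

In an ADME assay on MOLT-3 cells (Homo sapiens) for cytotoxicity, with a stated time of 7 days (on this read-out lower numbers stand for higher toxicity in this test and higher numbers for lower toxicity in this test), three compounds with a shared core have entries: compound 1 `Nc1nc(NC2CCCCC2)c2ncn(/C=C3/CC3(CO)CO)c2n1`, compound 2 `Nc1nc(OCC(F)(F)F)c2ncn(/C=C3/CC3(CO)CO)c2n1` and compound 3 `Nc1nc2c(ncn2/C=C2/CC2(CO)CO)c(=O)[nH]1`. In this assay compound 1 gives "not determined" (no result reported). In this assay compound 2 gives > 20000 nM, which is a limit of the assay and not a number. Compound 3 also reaches only a limit in this assay, > 20000 nM. Compound 2 thus stands at the limit of > 20000 nM in this assay, at which 2 of the 3 values shown sit, while the remaining entry carries no number, so no order among the three can be drawn from these values.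

Compound 4 `Nc1nc(SCc2ccccc2)c2ncn(/C=C3/CC3(CO)CO)c2n1` has not yet been measured. It differs from compound 2 in one place: benzylsulfanyl in place of 2,2,2-trifluoroethoxy on an aromatic carbon. Going by the values given here, no step between measured compounds is available, and both measured values are limits, so the step from compound 2 to compound 4 in this assay has no comparison to rest on; the author expects no step beyond the scatter. The estimate for compound 4 in this assay is 25000 nM, expected to lie between 8000 nM and 80000 nM. The expected step is a step that the limit leaves unreadable from compound 2 to compound 4.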

Compound 4, half-maximal cytotoxic concentration: > 20000 nM
Compound 4: no number, only a limit; the forecaster's own chance of this, stated with the estimate: 70%; the middle value does not contradict the limit.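

In this assay, going by these compounds alone, compound 4 reaches only a limit of the assay and not a number, as compound 2 does, so no step between compound 2 and compound 4 can be read: the limit of > 20000 nM in this assay, at which 3 of the 4 values shown sit. The compounds shown leave open at what concentration, if any, either of these two becomes cytotoxic to these cells.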